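The compounds below may be only part of what the source reports. "The series", "measured", "known", "first", "only" and "open" are said of these compounds alone.

Measured compounds:
compound 1, `O=C(O)c1ccccc1-c1ccc(CCc2ncc(CC3CCCCCC3)[nH]2)cc1`, 88 nM
compound 2, `COc1ccccc1Cc1cnc(CCc2ccc(-c3ccccc3C(=O)O)cc2)[nH]1`, 1720 nM
compound 3, `Cc1ccccc1Cc1cnc(CCc2ccc(-c3ccccc3C(=O)O)cc2)[nH]1`, 127 nM

In an in vitro functional assay on cells for agonist activity at Bombesin receptor subtype-3 (Homo sapiens), read by luminescence and calcium flux (a lower number here means that less compound is needed, a higher number that more compound is needed for the effect), compound 3 holds the second highest of the three numbers. Its nearest neighbour is compound 1, and the step of a 1.4-fold higher number from compound 1 to compound 3 (0.16 log units; within the scatter) lies within the scatter, so the two cannot be ordered. Compound 2 stands furthest away, the step of a 14-fold lower number from compound 2 to compound 3 (1.13 log units; beyond the scatter) being large and beyond the scatter.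

Compound 4, `O=C(O)c1ccccc1-c1ccc(CCc2ncc(C3CCCCC3)[nH]2)cc1`, differs from compound 3 in one place: cyclohexyl in place of 2-methylbenzyl on an aromatic carbon. The step that bears on this is a 1.4-fold higher number from compound 1 to compound 3 (0.16 log units; within the scatter), where a saturated carbon ring and a 2-methylphenyl traded places with hardly any movement in the number. The steps involving compound 2 concern the methoxy group and do not inform this change. Among the compounds with values here, the saturated ring of compound 4 is smaller than that of compound 1 and sits directly on the aromatic carbon, which adds uncertainty, but no step in the data suggests a large move. For compound 4 the expected step is a 1.1-fold lower number from compound 3 to compound 4 (0.02 log units; within the scatter), not beyond the scatter. Compound 4 is therefore estimated at 120 nM, with a range of 40 nM to 400 nM.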

Compound 4, half-maximal effective concentration: 375 nM
Compound 4: the middle estimate sits 3.1-fold (0.49 log units) below what was measured; the measured number falls inside the stated range.
By their numbers in this assay, from the lowest: compounds 1 and 3 (each within the scatter of the next); then compound 4; then compound 2.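

On this aromatic carbon of the five-membered ring, cyclohexyl does not match the two groups that had been indistinguishable: this assay shows a 3.0-fold higher number from compound 3 to compound 4 (0.47 log units; beyond the scatter) and a 4.3-fold higher number from compound 1 to compound 4 (0.63 log units; beyond the scatter), both modest and beyond the scatter. Cyclohexyl nevertheless compares well with 2-methoxybenzyl, with a 4.6-fold lower number from compound 2 to compound 4 (0.66 log units; beyond the scatter), so compound 4 falls in the middle of the series rather than at its high end. A saturated ring therefore does not fix the number here, since compound 1 and compound 4 both carry one and still differ.

The step from cycloheptylmethyl to cyclohexyl alters the ring and removes the linking carbon together, and a cyclohexylmethyl group or a phenyl group in this place would be needed to separate those changes. What lies behind these shifts is not explained by any evidence available here.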